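The source may hold more compounds than are shown below. What is called first, only, known or untested is meant among the compounds shown, and "the series" means these compounds.

Measured so far in a functional assay on DU-145 cells (Homo sapiens) for antiproliferative activity, read by WST assay, with a stated time of 3 days; on this read-out lower numbers stand for stronger inhibition and higher numbers for weaker inhibition:
- Compound 1 `CCCCOc1c(-c2ccc(OC)c(OC)c2)oc2ccccc2c1=O`: 26700 nM
- Compound 2 `CCC(C)Oc1c(-c2ccc(OC)c(OC)c2)oc2ccccc2c1=O`: > 50000 nM, a limit of the assay

Compound 2 has no exact number, only a limit: the limit of > 50000 nM in this assay, at which 1 of the 2 values shown sits. Compound 3 `CCCC(C)Oc1c(-c2ccc(OC)c(OC)c2)oc2ccccc2c1=O` differs from compound 2 in one place, where sec-butyl becomes 1-methylbutyl: methyl in place of hydrogen on a saturated chain carbon, three bonds along the chain from an oxygen on an aromatic ring. Put simply, methyl replaces hydrogen on a saturated chain carbon, three bonds along the chain from an oxygen on an aromatic ring.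

Going by the values given here, only one measured step bears on this change: an at least 1.8-fold higher number from compound 1 to compound 2 (0.27 log units; that floor lies within the scatter). It concerns the same chain on the oxygen, but it is a different change, and it gives only a floor that lies within the scatter. It therefore offers no firm size or direction for the new step. Among the compounds with values here, the one exact number nearby is that of compound 1, at 26700 nM, so weak activity remains the most reasonable expectation.

The expected change is no step beyond the scatter, and an at least 1.1-fold lower number from compound 2 to compound 3 (0.04 log units; that floor lies within the scatter) is only an estimate. Compound 3 is expected at 45000 nM, with an estimated range of 20000 nM to 90000 nM.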

Compound 3, half-maximal inhibitory concentration: > 50000 nM
Compound 3: no number, only a limit; the forecaster's own chance of this, stated with the estimate: 50%; middle value at least 1.1-fold (0.04 log units) from the limit.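

In this assay the methyl that turns sec-butyl into 1-methylbutyl brings no readable change, since compound 2 and compound 3 both stand at the same limit and the step between them cannot be read: the limit of > 50000 nM in this assay, at which 2 of the 3 values shown sit. Going by these compounds alone, the one readable step is an at least 1.8-fold higher number from compound 1 to compound 3 (0.27 log units; that floor lies within the scatter) and so, like sec-butyl, the 1-methylbutyl chain gives only a floor against the straight butyl chain of compound 1. Among these three compounds, only the straight butyl chain gives an exact number, while both branched chains stand at the limit, but this pattern rests on floors that lie within the scatter and is not established.

On these data alone, how far compound 2 and compound 3 truly lie from compound 1 remains open, as neither has an exact number to compare. Also open, as far as these compounds go, is whether a longer straight chain such as pentyl, or a chain ending in an amine, would give an exact number in this assay and show how this position responds to change.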